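A few compounds are considered here, and "the series" means these few. Any claim that something is new, unique, unknown or untested is made for them only; others in the source may bear on it.

Working notes on a small set run in an assay for inhibition of phosphatidylcholine:ceramide cholinephosphotransferase 2 (Mus musculus), read by mass spectrometry, with stated times of 60 min and 30 min; on this read-out lower numbers stand for stronger inhibition and higher numbers for weaker inhibition. Compound 1 `CC(C)CCOc1c(C(=O)N(C)Cc2cc(C(F)(F)F)cc(C(F)(F)F)c2)c(=O)n(C)c2ccccc12` gives 260 nM. Compound 2 `COc1cc(CN(C)C(=O)c2c(OCCCC3CCN(C(=O)OC(C)(C)C)CC3)c3cnccc3n(C)c2=O)cc(OC)c1` gives 340 nM, a number that sits with that of compound 1 inside the usual scatter. Compound 3 `COc1cc(CN(C)C(=O)c2c(OCCCC3CCN(C(=O)OC(C)(C)C)CC3)c3cccnc3n(C)c2=O)cc(OC)c1` gives 32 nM, a lower number than either of the other two and beyond the scatter from compound 1. On these three numbers compound 1 stands second highest, with compound 2 nearest to it and compound 3 furthest.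

Compound 4 `CN(Cc1cc(C(F)(F)F)cc(C(F)(F)F)c1)C(=O)c1c(OCCCC(F)(F)F)c2ccccc2n(C)c1=O` has not yet been measured in this assay. It differs from compound 1 in one place: 2,2,2-trifluoroethyl in place of isopropyl on a saturated chain carbon, two bonds along the chain from an oxygen on an aromatic ring. Among the measured compounds shown here, no measured pair in the set carries this same change, so the data give no precedent for its direction or size. The step expected in this assay is a 1.2-fold higher number from compound 1 to compound 4 (0.06 log units; within the scatter), that is, none beyond the scatter in either direction. Compound 4 is therefore estimated at 300 nM, with a range from 110 nM to 850 nM.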

Compound 4, half-maximal inhibitory concentration: 240 nM
Beside the measured number, compound 4's estimate is 1.3-fold (0.10 log units) above it, and the stated range covers the measured number.
By their numbers in this assay, from the lowest: compound 3; then compounds 4, 1 and 2 (each within the scatter of the next).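

In this assay, the change of isopropyl to 2,2,2-trifluoroethyl on a saturated chain carbon, two bonds along the chain from an oxygen on an aromatic ring, gives a 1.1-fold lower number from compound 1 to compound 4 (0.03 log units; within the scatter). Among the compounds shown here, this is the first pair in the set that differs in one place, and it shows that, on the core of compound 1, this position accepts either isopentyloxy or 4,4,4-trifluorobutoxy with no change that the read-out can separate. Nothing available bears on why the two chain ends read alike.

On these data alone, whether a primary amine, a carboxylic acid or a longer chain at this end would also stay within the scatter of compound 1 remains open. A single pair sets no pattern, so the same change on the core of compound 3 also remains an open question.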